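The source may hold more compounds than are shown below. What is called first, only, known or untested is meant among the compounds shown, and "the series" means these compounds.

Measured so far in a functional assay on PC-3 cells (Homo sapiens) for inhibition, read by sulforhodamine B assay; a lower number here means a stronger inhibitor of growth, a higher number a weaker inhibitor of growth:
- compound 1 `COc1ccc(-c2ccc(-c3ccc(-c4nc5cc(C)ccc5[nH]4)cc3)cc2)cc1OC`: 2560 nM
- compound 2 `COc1cc(-c2ccc(-c3ccc(-c4nc5cc(C)ccc5[nH]4)cc3)cc2)cc(OC)c1OC`: 180 nM
- compound 3 `COc1ccc(-c2ccc(-c3ccc(-c4nc5ccccc5[nH]4)cc3)cc2)cc1OC`: 47100 nM

Compound 1 has the second highest of the three numbers. The next compound, compound 4 `Cc1ccc2[nH]c(-c3ccc(-c4ccc(-c5ccc(F)cc5)cc4)cc3)nc2c1`, differs from it as follows: 4-fluorophenyl in place of 3,4-dimethoxyphenyl on an aromatic carbon. This puts 4-fluorophenyl in place of 3,4-dimethoxyphenyl on an aromatic carbon.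

For the measured compounds named here, two measured steps bear on this change. The closer one is a 14-fold lower number from compound 1 to compound 2 (1.15 log units; beyond the scatter), with methoxy in place of hydrogen on an aromatic carbon in the group that changes here. The other is an 18-fold higher number from compound 1 to compound 3 (1.26 log units; beyond the scatter), with hydrogen in place of methyl on an aromatic carbon. It shows only that a small edit can move this assay a long way in this series. Going by the values given here, no measured step exchanges methoxy for fluorine. Compound 4 carries no methoxy, so a moderate step toward a higher number is expected, given the direction of a 14-fold lower number from compound 1 to compound 2 (1.15 log units; beyond the scatter). The expected change is a 2.3-fold higher number from compound 1 to compound 4 (0.37 log units; beyond the scatter). For compound 4 the estimated value is 6000 nM, with an expected range of 1200 nM to 30000 nM.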

Compound 4, concentration for 50% growth inhibition: 100000 nM
The estimate for compound 4 lay 17-fold (1.22 log units) below the measured number; the whole stated range lies below it.
By their numbers in this assay, from the lowest: compound 2; then compound 1; then compound 3; then compound 4.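

In this assay, 4-fluorophenyl in place of 3,4-dimethoxyphenyl on this aromatic carbon gives a 39-fold higher number from compound 1 to compound 4 (1.59 log units; beyond the scatter), so the group at this position can move growth inhibition strongly toward a higher number as well as toward a lower one. The earlier compounds shown here showed only that adding a methoxy here lowers the number; this change removes the methoxy groups and brings in fluorine in a single edit, and its effect is of similar or greater size than the earlier steps. Nothing available explains why the number rises at this position.

The loss of methoxy and the entry of fluorine cannot be separated with the compounds shown. An unsubstituted phenyl, or a phenyl carrying a single methoxy or an amine, would help to tell these two contributions apart.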